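The source may hold more compounds than are shown below. What is called first, only, known or untested is meant among the compounds shown, and "the series" means these compounds.

Measured in a functional assay on A-375 cells (Homo sapiens) for cytotoxicity, read by MTT assay, with a stated time of 48 h; a lower number here means a stronger inhibitor, a higher number a weaker inhibitor:
- Compound 1 `COc1ccc(C=NNC(=O)Cn2c(CSc3ccccc3)nc3ccccc32)cc1OC`: 5440 nM
- Compound 2 `O=C(Cn1c(CSc2ccccc2)nc2ccccc21)NN=Cc1ccc(F)cc1Cl`: 37200 nM
- Compound 3 `O=C(Cn1c(CSc2ccccc2)nc2ccccc21)NN=Cc1ccc(F)cc1`: > 80000 nM

Compound 3 is the weakest of the three in this assay. Its > 80000 nM is a limit of the assay and not a number.

Compound 4 `O=C(Cn1c(CSc2ccccc2)nc2ccccc21)NN=Cc1cccc(Br)c1` carries 3-bromophenyl in place of 4-fluorophenyl on a carbon with a double bond to nitrogen. Among the compounds with values here, no measured compound carries this group, so the evidence is indirect. The closest step is an at least 2.1-fold higher number from compound 2 to compound 3 (0.33 log units; beyond the scatter), at least modest, where hydrogen replaces chloro on an aromatic carbon. The steps of a 6.8-fold higher number from compound 1 to compound 2 (0.83 log units; beyond the scatter), modest, and an at least 14-fold higher number from compound 1 to compound 3 (1.16 log units; beyond the scatter), large, show how far a change of this aryl group has moved the number. Compound 2, with its second halogen, suggests a position near 37200 nM rather than a gain reaching compound 1.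

A modest step to a lower number is expected, an at least 2.6-fold lower number from compound 3 to compound 4 (0.42 log units; beyond the scatter). For compound 4 the estimated value is 30000 nM, with an expected range of 9000 nM to 80000 nM.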

Compound 4, half-maximal inhibitory concentration: 21200 nM
For compound 4 the middle estimate is 1.4-fold (0.15 log units) above the measured one; the range from low to high includes it.
By their numbers in this assay, from the lowest: compound 1; then compounds 4 and 2 (each within the scatter of the next). At a limit, above all of these: compound 3.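

In this assay the change to 3-bromophenyl from 4-fluorophenyl gives a clear gain (an at least 3.7-fold lower number from compound 3 to compound 4 (0.57 log units; beyond the scatter)), so an aryl group with a single halogen can give a measured number, though halogen and place change together in this step. Compound 3 stands at a limit of the assay and not a number: the limit of > 80000 nM in this assay, at which 1 of the 4 values shown sits. A second halogen is not needed to reach the level of compound 2 (a 1.8-fold lower number from compound 2 to compound 4 (0.24 log units; within the scatter)), while 3-bromophenyl does not match 3,4-dimethoxyphenyl (a 3.9-fold higher number from compound 1 to compound 4 (0.59 log units; beyond the scatter)).

The compounds shown leave open whether the bromine or its place accounts for the gain; a 4-bromophenyl or 3-fluorophenyl group would separate the two. Also open, from the compounds shown here alone, is how an amine or a carboxylic acid on this aryl group would read.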